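Methyl on the triazole aryl: compound 3 to compound 4

A few compounds are considered here, and "the series" means these few. Any claim that something is new, unique, unknown or untested is made for them only; others in the source may bear on it.

Compound 3 `Cc1cccc(-n2nncc2CN2C(=O)C3(C(C#N)=C(N)Oc4c(N)cc5nc6ccccc6nc5c43)c3ccccc32)c1` has the lowest of the two numbers shown in a functional assay on A549 cells (Homo sapiens) for antiproliferative activity, read by MTT assay, with a stated time of 48 h; a lower number here means a stronger inhibitor, a higher number a weaker inhibitor: compound 3 gives 12300 nM. Its nearest neighbour is compound 2 `CCOc1ccc(-n2nncc2CN2C(=O)C3(C(C#N)=C(N)Oc4c3c3nc5ccccc5nc3c3ccccc43)c3ccccc32)cc1`, which in this assay gives 25200 nM, a step beyond the scatter. Compound 1 `N#CC1=C(N)Oc2c(c3nc4ccccc4nc3c3ccccc23)C12C(=O)N(Cc1cnnn1-c1ccc(Cl)cc1)c1ccccc12` sits at a limit of this assay, > 50000 nM, not at a number (the limit of > 50000 nM in this assay, at which 1 of the 3 values shown sits).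

Compound 4 `Cc1ccc(C)c(-n2nncc2CN2C(=O)C3(C(C#N)=C(N)Oc4c(N)cc5nc6ccccc6nc5c43)c3ccccc32)c1` differs from compound 3 by methyl in place of hydrogen on an aromatic carbon; cut one bond further out, the aryl on the triazole goes from 3-methylphenyl to 2,5-dimethylphenyl.

Within the data shown here, the only measured step on this aryl is an at least 1.9-fold lower number from compound 1 to compound 2 (0.29 log units; that floor lies within the scatter); it starts from a limit and its floor is within the scatter, so it shows no firm effect of a substituent there. Among the measured compounds shown here, the other two compounds carry a different core, so no step isolates the methyl.

Compound 4 is therefore expected to stay close to compound 3, an estimated step of a 1.1-fold lower number from compound 3 to compound 4 (0.05 log units; within the scatter). The estimate for compound 4 in this assay is 11000 nM, expected between 4000 nM and 30000 nM.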

Compound 4, half-maximal inhibitory concentration: > 50000 nM
Compound 4 was reported as a limit (the forecaster's own chance of this, stated with the estimate: 5%); at least 4.5-fold (0.65 log units) between middle value and limit.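

In this assay, among these compounds, the change to 2,5-dimethylphenyl gives an at least 4.0-fold higher number from compound 3 to compound 4 (0.60 log units; beyond the scatter), the one step on this aryl that lies beyond the scatter. The earlier step on the aryl, an at least 1.9-fold lower number from compound 1 to compound 2 (0.29 log units; that floor lies within the scatter), starts from a limit and has its floor within the scatter, and it belongs to a different core. The added methyl sits on an aromatic carbon ortho to a large group and para to a methyl group, and compound 4 stands at a limit, not at a number, so the step gives only a floor: the limit of > 50000 nM in this assay, at which 2 of the 4 values shown sit.

Open, on these data alone, is whether the step comes from the new methyl alone or depends on the methyl already present, which a 2-methylphenyl on the same core would separate. Also open, as far as these compounds go, is how a fluorine atom or a hydroxyl would read at that carbon.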